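This account rests on a few compounds, and the source may have more. Where it says the series, first, only, none or still open, it means among the compounds named here.

Measured in a functional assay on HL-60 cells (Homo sapiens) for inhibition, read by luminescence, with a stated time of 72 h, tested at 5 uM; on this read-out lower numbers stand for less inhibition of growth and higher numbers for more inhibition of growth at the one concentration tested:
- Compound 1 `C=CS(=O)(=O)NC/C=C/c1cc(OC)cc(O)c1C(=O)OCC1CCCCC1`: 7.5%
- Compound 2 `COc1cc(O)c(C(=O)OCC(C)c2ccccc2)c(/C=C/CN2C(=O)C=CC2=O)c1`: 56%
- Compound 3 `CCN(CC)C/C=C/C(=O)NC/C=C/c1cc(OCCc2ccc(F)cc2)cc(O)c1C(=O)OC(C)C`: 36.8%

Compound 1 stands lowest of the three. Compound 3 is nearest above it and compound 2 furthest, both beyond the usual scatter. Compound 4 `C=CS(=O)(=O)NC/C=C/c1cc(OC)cc(O)c1C(=O)OCc1ccc(F)cc1` keeps the core of compound 1 and changes one group: 4-fluorophenyl in place of cyclohexyl on a saturated chain carbon bound to an oxygen next to a carbonyl group. In words, 4-fluorophenyl comes in place of cyclohexyl on a saturated chain carbon bound to an oxygen next to a carbonyl group. Among the measured compounds shown here, no measured pair differs in one place only, so the expectation starts from compound 1 at 7.5%. Expected is a number 7.5 percentage points higher from compound 1 to compound 4 (within the scatter), a small upward step that may stay within the scatter. Compound 4 is estimated at 15%, with an expected range of 2% to 38%.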

Compound 4, percent growth inhibition at one concentration: 10.9%
Beside the measured number, compound 4's estimate is 4.1 percentage points above it; low and high end bracket the measured number.
By their numbers in this assay, from the lowest: compounds 1 and 4 (each within the scatter of the next); then compound 3; then compound 2.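

In this assay, among the compounds shown here, putting 4-fluorophenyl in place of cyclohexyl on a saturated chain carbon bound to an oxygen next to a carbonyl group gives a number 3.4 percentage points higher from compound 1 to compound 4 (within the scatter) and this is the first comparison in which only this place differs. On this read-out, the saturated ring and the aromatic ring cannot be told apart here. Nothing measured on these compounds explains this result.

From the compounds shown here alone, whether a ring is needed at this place stays open. So does how an amine, a carboxylic acid or a longer chain there would read.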